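This account rests on a few compounds, and the source may have more. Where it says the series, first, only, none or still open, it means among the compounds named here.

Measured so far in a functional assay on HT-29 cells (Homo sapiens) for antiproliferative activity, read by sulforhodamine B assay, with a stated time of 48 h; on this read-out higher numbers stand for weaker inhibition and lower numbers for stronger inhibition:

- compound 1 `COc1ccccc1OS(=O)(=O)c1ccc(N2CCN(C)C2=O)cc1` gives 26000 nM
- compound 2 `Cc1cccc(OS(=O)(=O)c2ccc(N3CCN(C)C3=O)cc2)c1` gives 4300 nM
- compound 3 `CCCN1CCN(c2ccc(S(=O)(=O)Oc3ccccc3OC)cc2)C1=O` gives > 100000 nM (a limit of the assay, not a number)

Compound 3 therefore has no exact value and stands at the assay's limit (the limit of > 100000 nM in this assay, at which 1 of the 3 values shown sits). Compound 4 `CCCN1CCN(c2ccc(S(=O)(=O)Oc3cccc(C)c3)cc2)C1=O` differs from compound 3 by a single exchange on an oxygen whose other neighbour is the sulfonyl sulfur, with 3-methylphenyl in place of 2-methoxyphenyl (3-methylphenyl in place of 2-methoxyphenyl on an oxygen).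

The same exchange has been measured once, and it lowered the number (a 6.0-fold lower number from compound 1 to compound 2 (0.78 log units; beyond the scatter)). The other measured step raised the number (an at least 3.8-fold higher number from compound 1 to compound 3 (0.58 log units; beyond the scatter)), and compound 3 and compound 4 both carry the chain it introduced. A drop of similar, modest size is thus expected in this assay, although it rests on one pair and starts from a limit. In numbers, the expected change is an at least 3.3-fold lower number from compound 3 to compound 4 (0.52 log units; beyond the scatter). Compound 4 is estimated at 30000 nM within an expected range of 14000 nM to 90000 nM.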

Compound 4, half-maximal inhibitory concentration: 65000 nM
Compound 4: the middle estimate sits 2.2-fold (0.34 log units) below what was measured, and the stated range covers the measured number.
By their numbers in this assay, from the lowest: compound 2; then compound 1; then compound 4. At a limit, above all of these: compound 3.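

In this assay, the exchange of 2-methoxyphenyl for 3-methylphenyl on the oxygen now has a second reading, an at least 1.5-fold lower number from compound 3 to compound 4 (0.18 log units; that floor lies within the scatter), so the lower number seen on the first core is not contradicted on the core with the longer chain, but the size of the drop there stays unsettled: the same change on two cores in this assay, a 6.0-fold lower number (0.78 log units; beyond the scatter) from compound 1 to compound 2 and an at least 1.5-fold lower number (0.18 log units; that floor lies within the scatter) from compound 3 to compound 4; the limit leaves it open whether they differ

The chain change can now also be read between two exact numbers, as a 15-fold higher number from compound 2 to compound 4 (1.18 log units; beyond the scatter), a large step where there was only a floor before: the same change on two cores in this assay, an at least 3.8-fold higher number (0.58 log units; beyond the scatter) from compound 1 to compound 3 and a 15-fold higher number (1.18 log units; beyond the scatter) from compound 2 to compound 4; the limit leaves it open whether they differ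

The value of compound 3, > 100000 nM, is a limit of the assay.

Still open, as far as these compounds go, is whether the exchange on the oxygen truly gives a smaller drop on the core with the longer chain than on the first core. Also open, from the compounds shown here alone, is how an amine or a carboxylic acid in place of the methyl of 3-methylphenyl would read.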